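Testing a Fluorocyclobutyl Amide in a Thiazole Alkyne Series

The source may report more compounds than this note shows. Statements on the series, on what has been measured and on what is new or still open speak of the compounds shown alone.

Compound 1, `O=C1NCCc2nc(C#Cc3cccc(F)c3)sc21`: in an assay on HEK293 cells for negative allosteric modulation of metabotropic glutamate receptor 5 (Homo sapiens), read by FLIPR, with a stated time of 1 h (on this read-out lower numbers stand for stronger inhibition and higher numbers for weaker inhibition), compound 1 gives > 10000 nM, a limit of the assay rather than a number.
Compound 2, `COc1ccccc1C#Cc1nc2c(s1)C(=O)NCC2`: in this assay compound 2 gives > 10000 nM, again a limit.
Compound 3, `CCC(=O)N1CCc2nc(C#Cc3ccccc3)sc2C1`: in this assay compound 3 gives 38 nM.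

Within the data shown here, compound 3 is therefore the only compound here with a measured number; the other two sit at the limit of > 10000 nM in this assay, at which 2 of the 3 values shown sit, and no step between measured compounds can be read from them.

Compound 4, `O=C(C1CC(F)C1)N1CCc2nc(C#Cc3ccccc3)sc2C1`, differs from compound 3 in one place: 3-fluorocyclobutyl in place of ethyl on a carbonyl carbon, or propanoyl becoming (3-fluorocyclobutyl)carbonyl. Among the measured compounds shown here, nothing among the measured compounds shows what such a change does, so the expectation rests on compound 3 alone.

The expected step from compound 3 to compound 4 is a 1.3-fold lower number from compound 3 to compound 4 (0.10 log units; within the scatter), which is taken to stay within the usual scatter. Compound 4 is expected to give about 30 nM, with a plausible range from 8 nM to 120 nM.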

Compound 4, half-maximal inhibitory concentration: > 10000 nM
Compound 4: no number, only a limit; the forecaster's own chance of this, stated with the estimate: 5%; middle value at least 330-fold (2.52 log units) from the limit.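

Compound 3 showed that a small acyl group on the ring nitrogen is compatible with a measured number, and compound 4 shows that this position does not accept every acyl group. In this assay, putting 3-fluorocyclobutyl in place of ethyl on the carbonyl carbon gives an at least 260-fold higher number from compound 3 to compound 4 (2.42 log units; beyond the scatter), a large step from one change in an otherwise identical structure. Compound 4 gives > 10000 nM, which is a limit of the assay and not a number, so the true size of the step stays unknown, and compound 4 cannot be ranked against the other compounds that sit there: the limit of > 10000 nM in this assay, at which 3 of the 4 values shown sit.

The compounds shown leave open whether the fluorine, the four-membered ring or the larger group as a whole accounts for the step. A plain cyclobutyl or a propyl group on the same carbonyl carbon would help tell these apart.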